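Compound 4 in a weakly active series

The source may report more compounds than this note shows. Statements on the series, on what has been measured and on what is new or still open speak of the compounds shown alone.

Measured so far in a functional assay on CWR22R cells (Homo sapiens) for antiproliferative activity, with a stated time of 96 h (a lower number here means a stronger inhibitor, a higher number a weaker inhibitor), for three compounds
compound 1 (`Cc1cc(=O)oc2cc(OCC(=O)c3ccc(C(C)(C)C)cc3)ccc12`) gives 22300 nM
compound 2 (`O=C(COc1ccc2c(C(F)(F)F)cc(=O)oc2c1)c1cccc(C(F)(F)F)c1`) gives "not active" (no number reported)
compound 3 (`O=C(COc1ccc2c(C(F)(F)F)cc(=O)oc2c1)c1ccccc1`) gives "not active" (no number reported)

Compound 3 has no single number ("not active" (no number reported)), and neither does compound 2. Only compound 1 (22300 nM) gives a figure to work from.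

The next compound to be read is compound 4 (`O=C(COc1ccc2c(C(F)(F)F)cc(=O)oc2c1)c1ccc(C(F)(F)F)cc1`). The change is trifluoromethyl in place of hydrogen on an aromatic carbon and puts trifluoromethyl in place of hydrogen on an aromatic carbon, para to a large group.

For the measured compounds named here, no measured pair sizes a step of this kind, and without a number for compound 3 the step can only be judged loosely. No large gain is expected in this assay. Compound 4 should remain weak, either close to compound 1 (22300 nM) or like compound 2 ("not active" (no number reported)) without a number.

If a number is reported, compound 4 is estimated at 30000 nM, with an expected range of 10000 nM to 90000 nM.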

Compound 4, half-maximal inhibitory concentration: "not active" (no number reported)
Compound 4 has no reported number here, so the estimate cannot be set against anything.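

Compound 3 and compound 4 both lack a number in this assay, so no step can be read for trifluoromethyl in place of hydrogen. No evidence on hand bears on this result. The compounds shown leave open whether this change shifts activity at all.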